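Swapping a pentyl chain for a benzyl group

This account rests on a few compounds, and the source may have more. Where it says the series, first, only, none or still open, it means among the compounds named here.

Of the compounds shown here, three built on one shared core have been tested in a functional assay on A549 cells (Homo sapiens) for cytotoxicity, read by MTT assay, with a stated time of 72 h; a lower number here means a stronger inhibitor, a higher number a weaker inhibitor. Compound 1 `O=[N+]([O-])c1cccc(COCNc2n[n+]([O-])c3ccccc3[n+]2[O-])c1` gives 2890 nM. Compound 2 `COc1ccc2c(c1)[n+]([O-])nc(NCOCc1ccccc1)[n+]2[O-]` gives 2500 nM. Compound 3 `CCCCCOCNc1n[n+]([O-])c2ccccc2[n+]1[O-]` gives 6460 nM, the highest of the three numbers; its nearest neighbour is compound 1, whose number lies below it by more than the scatter, and compound 2 lies further below still. Compound 4 `[O-][n+]1nc(NCOCc2ccccc2)[n+]([O-])c2ccccc21` has not yet been measured. It differs from compound 3 in one place: phenyl in place of butyl on a saturated chain carbon bound to an oxygen on a saturated carbon. Compound 1 and compound 2 both carry this benzyl group on the same core, each with one additional group elsewhere in the structure, and both sit beyond the scatter below compound 3. On that basis compound 4 is expected to give a lower number than compound 3, by a step of roughly the size seen between compound 3 and compound 1. The expected step is a 2.3-fold lower number from compound 3 to compound 4 (0.36 log units; beyond the scatter). The estimate for compound 4 is 2800 nM, with a range from 1400 nM to 5600 nM.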

Compound 4, half-maximal inhibitory concentration: 10800 nM
For compound 4 the middle estimate is 3.9-fold (0.59 log units) below the measured one, outside the stated range (above it).
By their numbers in this assay, from the lowest: compounds 2 and 1 (each within the scatter of the next); then compounds 3 and 4 (each within the scatter of the next).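

In this assay, exchanging pentyl for benzyl with nothing else altered gives a 1.7-fold higher number from compound 3 to compound 4 (0.22 log units; within the scatter) and so does not separate the two compounds beyond the scatter. The lower numbers of compound 1 and compound 2 therefore do not come with the benzyl group alone: hydrogen in place of methoxy on an aromatic carbon gives a 4.3-fold higher number from compound 2 to compound 4 (0.64 log units; beyond the scatter) and hydrogen in place of nitro on an aromatic carbon gives a 3.7-fold higher number from compound 1 to compound 4 (0.57 log units; beyond the scatter), both modest steps beyond the scatter. No measurement shown here explains the size of any of these steps.

From the compounds shown here alone, whether a methoxy or nitro group would lower the number of the pentyl compound as well remains open. So does the effect of a cyclohexyl group or a longer chain in place of pentyl.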